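This account rests on a few compounds, and the source may have more. Where it says the series, first, only, none or still open, it means among the compounds named here.

Compound 1 `O=C1N=C(N2N=C(c3ccccc3)CC2c2ccccc2O)S/C1=C1/C(=O)Nc2ccccc21` gives 3190 nM in a functional assay on cells (Leukemia cell, Homo sapiens) for cytotoxicity, read by sulforhodamine B assay, with a stated time of 48 h (a lower number here means a stronger inhibitor of growth, a higher number a weaker inhibitor of growth), the highest of the three numbers here. Compound 2 `O=C1N=C(N2N=C(c3ccccc3)CC2c2ccccc2O)S/C1=C1/C(=O)Nc2ccc(Br)cc21` gives 270 nM, and compound 3 `Cc1ccc2c(c1)/C(=C1\SC(N3N=C(c4ccccc4)CC3c3ccc(Cl)cc3)=NC1=O)C(=O)N2` gives 390 nM. Compound 4 `CN(C)c1ccc(C2CC(c3ccccc3)=NN2C2=NC(=O)/C(=C3\C(=O)Nc4ccccc43)S2)cc1` differs from compound 1 by one change: 4-(dimethylamino)phenyl in place of 2-hydroxyphenyl on a saturated ring carbon. Within the data shown here, the only single-place step measured, a 12-fold lower number from compound 1 to compound 2 (1.07 log units; beyond the scatter), lies elsewhere on the core and so does not bear directly on this change; compound 3 differs from compound 1 in two places, one on the same saturated ring carbon, and its value with that of compound 1 shows only a lower number. A modest lowering is therefore expected, as a 2.1-fold lower number from compound 1 to compound 4 (0.33 log units; beyond the scatter). For compound 4 the estimate is 1500 nM, within 500 nM to 5000 nM.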

Compound 4, concentration for 50% growth inhibition: 33900 nM
Compound 4: middle estimate off by 23-fold (1.35 log units), on the low side, outside the stated range (above it).
By their numbers in this assay, from the lowest: compounds 2 and 3 (each within the scatter of the next); then compound 1; then compound 4.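

In this assay, this saturated ring carbon proves sensitive to its aryl group: 4-(dimethylamino)phenyl in place of 2-hydroxyphenyl gives an 11-fold higher number from compound 1 to compound 4 (1.03 log units; beyond the scatter), so the change weakens growth inhibition. The step is large, as is the bromo step on the other side of the core, but it runs in the opposite direction. Nothing available explains this loss.

This one swap removes the hydroxyl and adds the dimethylamino group together, so their separate contributions cannot be told apart. A plain phenyl or a 2-methoxyphenyl at this carbon would help separate them.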